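The source may report more compounds than this note shows. Statements on the series, on what has been measured and on what is new or still open speak of the compounds shown alone.

Compound 1 `Cc1ccc(C2=NN(C3=NC(=O)CS3)C(c3ccc4ccccc4c3)C2)cc1`: 12700 nM
Compound 2 `Fc1ccc(C2=NN(C3=NC(c4ccccc4)CS3)C(c3ccc4ccccc4c3)C2)cc1`: 26500 nM
Compound 3 `O=C1CSC(N2N=C(c3ccc(Br)cc3)CC2c2ccc3ccccc3c2)=N1`: 18200 nM

All three were tested in a functional assay on HepG2 cells (Homo sapiens) for inhibition, read by CCK-8 assay, with a stated time of 48 h; a higher number here means a weaker inhibitor, a lower number a stronger inhibitor. The value of compound 3 lies within the usual scatter of the values of both compound 1 and compound 2. Compound 4 `O=C1CSC(N2N=C(c3ccc(F)cc3)CC2c2ccc3ccccc3c2)=N1` differs from compound 3 in one group: fluoro in place of bromo on an aromatic carbon. This puts fluoro in place of bromo on an aromatic carbon. For the measured compounds named here, the one measured step at this spot is a 1.4-fold higher number from compound 1 to compound 3 (0.16 log units; within the scatter), with bromo in place of methyl, and it stays within the scatter. Compound 2 also carries a 4-fluorophenyl group, but the rest of its structure differs, so it offers no clean comparison. No change beyond the scatter is therefore expected in this assay. The estimated change is a 1.1-fold lower number from compound 3 to compound 4 (0.03 log units; within the scatter). For compound 4, the expected value is 17000 nM, with an estimated range of 8000 nM to 35000 nM.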

Compound 4, half-maximal inhibitory concentration: 24100 nM
Compound 4: middle estimate off by 1.4-fold (0.15 log units), on the low side, and the stated range covers the measured number.
By their numbers in this assay, from the lowest: compounds 1, 3, 4 and 2 (each within the scatter of the next, the first and the last beyond it).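

In this assay, replacing bromo with fluoro gives a 1.3-fold higher number from compound 3 to compound 4 (0.12 log units; within the scatter) and replacing methyl with fluoro gives a 1.9-fold higher number from compound 1 to compound 4 (0.28 log units; within the scatter) on this aromatic carbon, so these three groups read alike here. Replacing the larger group on the ring amine nitrogen with a smaller one gives a 1.1-fold lower number from compound 2 to compound 4 (0.04 log units; within the scatter) and likewise shows no change beyond the scatter. No supporting evidence bears on these results. Still open, from the compounds shown here alone, is whether an amine or a carboxylic acid on this aromatic carbon would move the number beyond the scatter.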